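Moving a Ring Substituent: Expecting a Fourth Analogue

The compounds below may be only part of what the source reports. "The series", "measured", "known", "first", "only" and "open" are said of these compounds alone.

Compound 1: `O=C(CCl)NC(=O)Nc1ccc(OC2CCCCC2)cc1` gives 3100 nM
Compound 2: `O=C(CCl)NC(=O)Nc1cccc(OC2CCCCC2)c1` gives 3800 nM
Compound 3: `O=C(CCl)NC(=O)Nc1ccc(OC2CCCCCC2)cc1` gives 2300 nM

Of the compounds shown here, three have so far been tested in a functional assay on HT-29 cells (Homo sapiens) for inhibition, read by sulforhodamine B assay, with a stated time of 48 h; on this read-out lower numbers stand for stronger inhibition of growth and higher numbers for weaker inhibition of growth. Compound 1 and compound 2 are built from the same atoms joined differently; the difference between their two cores is not broken down here. Compound 3 carries the core of compound 1 and differs from it in one place: cycloheptyl in place of cyclohexyl on an oxygen on an aromatic ring. That change gave a 1.3-fold lower number from compound 1 to compound 3 (0.13 log units; within the scatter), so the two numbers cannot be told apart with confidence.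

Compound 4, `O=C(CCl)NC(=O)Nc1cccc(OC2CCCCCC2)c1`, has not yet been measured in this assay. It carries the core of compound 2 and differs from it in one place: cycloheptyl in place of cyclohexyl on an oxygen on an aromatic ring. The place of the change is described in the same words for both pairs, so this is the same change made on the other core.

Within the data shown here, with only one earlier example, and that example lying within the usual scatter, the expectation for compound 4 rests on compound 2 alone. Because compound 2 gives 3800 nM and the earlier change gave a 1.3-fold lower number from compound 1 to compound 3 (0.13 log units; within the scatter), the step to compound 4 is estimated as a 1.3-fold lower number from compound 2 to compound 4 (0.12 log units; within the scatter). Compound 4 is therefore expected to give about 2900 nM, most likely between 1500 nM and 6000 nM.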

Compound 4, concentration for 50% growth inhibition: 6900 nM
Compound 4: the middle estimate sits 2.4-fold (0.38 log units) below what was measured; the whole stated range lies below it.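

In this assay, putting cycloheptyl in place of cyclohexyl on the core of compound 2 gave a 1.8-fold higher number from compound 2 to compound 4 (0.26 log units; within the scatter). Set beside the same change on the core of compound 1, this step cannot be told apart from the earlier one: the same change on two cores in this assay, a 1.3-fold lower number (0.13 log units; within the scatter) from compound 1 to compound 3 and a 1.8-fold higher number (0.26 log units; within the scatter) from compound 2 to compound 4, 2.4-fold (0.39 log units) apart, within the scatter of two such steps. The two pairs therefore give no sign that the change behaves differently on the two cores, but they do not show that it carries over reliably, and with both steps inside the usual scatter, they do not show that it alters growth inhibition on either core.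

The compounds shown leave open what happens when the cyclohexyl or cycloheptyl on the oxygen gives way to a different kind of group, such as a cyclopentyl ring, a longer open chain or a chain ending in an amine. They also leave open whether any such group would produce a step beyond the scatter, and whether that step would then hold on both cores.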